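A few compounds are considered here, and "the series" means these few. Any claim that something is new, unique, unknown or untested is made for them only; others in the source may bear on it.

Working notes on the series. Compound 1 `N#CC1=C(N)Oc2c(c3nc4ccccc4nc3c3ccccc23)C12C(=O)N(Cc1cnnn1-c1cccc(S(N)(=O)=O)c1)c1ccccc12` carries a 3-sulfamoylphenyl on the aromatic nitrogen; in a functional assay on A549 cells (Homo sapiens) for antiproliferative activity, read by MTT assay, with a stated time of 48 h (a lower number here means a stronger inhibitor, a higher number a weaker inhibitor), compound 1 gives 44200 nM. Compound 2 `Cc1ccc(-n2nncc2CN2C(=O)C3(C(C#N)=C(N)Oc4c3c3nc5ccccc5nc3c3ccccc43)c3ccccc32)c(C)c1` carries 2,4-dimethylphenyl on that nitrogen in place of the 3-sulfamoylphenyl. In this assay compound 2 reaches only a limit, > 50000 nM, so no number stands for it. For the measured compounds named here, the single measured step, an at least 1.1-fold higher number from compound 1 to compound 2 (0.05 log units; that floor lies within the scatter), is known only as a floor, and that floor lies within the scatter. Compound 2 has no fixed place on the numbers shown because the limit of > 50000 nM in this assay, at which 1 of the 2 values shown sits, marks where it sits.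

Compound 3 `Cc1ccc(Cl)cc1-n1nncc1CN1C(=O)C2(C(C#N)=C(N)Oc3c2c2nc4ccccc4nc2c2ccccc32)c2ccccc21` follows from compound 2 by 5-chloro-2-methylphenyl in place of 2,4-dimethylphenyl on an aromatic nitrogen. Going by the values given here, only the step from compound 1 to compound 2 bears on this change, and it exchanged the whole aryl on the aromatic nitrogen without moving the number beyond the scatter. For compound 3 the aryl keeps one methyl and trades the other for chlorine, a smaller change than that measured step. In this assay the step from compound 2 is expected to be a step that the limit leaves unreadable from compound 2 to compound 3, that is, no movement beyond the scatter. Compound 3 is expected to give 60000 nM, with a range from 25000 nM to 150000 nM, and more likely than not only a limit again.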

Compound 3, half-maximal inhibitory concentration: > 50000 nM
Compound 3: no number, only a limit; the forecaster's own chance of this, stated with the estimate: 60%; the middle value does not contradict the limit.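

In this assay compound 3 gives > 50000 nM, which is a limit and not a number. Exchanging 3-sulfamoylphenyl for 5-chloro-2-methylphenyl on the aromatic nitrogen gives an at least 1.1-fold higher number from compound 1 to compound 3 (0.05 log units; that floor lies within the scatter), so this second replacement of the whole aryl is also known only as a floor and shows no movement beyond the scatter. The step from 2,4-dimethylphenyl to 5-chloro-2-methylphenyl cannot be read, so chlorine in place of one methyl has no measurable size here, and the new information is only that a chlorine-bearing aryl at this position also ends at the limit: the limit of > 50000 nM in this assay, at which 2 of the 3 values shown sit.

The compounds shown leave open how far compound 2 and compound 3 actually lie from compound 1, and whether the sulfamoyl group of compound 1 matters at all, since no step at this position is yet readable beyond the scatter. Also open, going by these compounds, is whether an aryl carrying an amine or a carboxylic acid, or a benzyl group on the same nitrogen, would bring a number clearly lower than that of compound 1.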